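This account rests on a few compounds, and the source may have more. Where it says the series, first, only, none or still open, it means among the compounds named here.

Measured so far:
compound 1, `Cn1ncc(Cl)c1-c1cc(C(=O)N[C@@H]2CNCC[C@H]2c2ccc(C(F)(F)F)cc2)oc1Cl`, 280 nM
compound 2, `Cn1ncc(Cl)c1-c1cc(C(=O)N[C@@H]2CN[C@H](CCO)C[C@H]2c2ccc(F)c(F)c2)oc1Cl`, 360 nM
compound 3, `CNC(=O)C[C@@H]1C[C@@H](c2ccc(F)c(F)c2)[C@H](NC(=O)c2cc(-c3c(Cl)cnn3C)c(Cl)o2)CN1`, 1100 nM

In a functional assay on HCT-116 cells (Homo sapiens) for antiproliferative activity, read by sulforhodamine B assay, with a stated time of 72 h (a higher number here means a weaker inhibitor, a lower number a stronger inhibitor), compound 2 gives 360 nM, the second highest of the three numbers. Compound 1 gives 280 nM, and the two values lie within the usual scatter of each other. Going by the values given here, compound 3 gives 1100 nM, and the one measured step, a 3.1-fold higher number from compound 2 to compound 3 (0.49 log units; beyond the scatter), is a modest change in the 2-hydroxyethyl group side of the shared core.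

Compound 4, `Cn1ncc(Cl)c1-c1cc(C(=O)N[C@@H]2CN[C@H](CCO)C[C@H]2c2ccc(Cl)c(Cl)c2)oc1Cl`, is not yet measured. It differs from compound 2 in one place: 3,4-dichlorophenyl in place of 3,4-difluorophenyl on a saturated ring carbon. This change sits on the aromatic ring bound to the saturated ring, not on the chain. Among the compounds with values here, no measured step touches that ring, so nothing measured bears directly on it; the only known step concerns a different part of the molecule. With no guidance from the data, the expectation is for no step beyond the scatter, in either direction.

Compound 4 is therefore expected to give about 360 nM, with a range from 150 nM to 900 nM. The step this estimate implies is expected to be no change at the digits printed from compound 2 to compound 4 (within the scatter).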

Compound 4, half-maximal inhibitory concentration: 340 nM
Estimate against measurement, compound 4: 1.1-fold (0.02 log units) above; measured number inside the range.
By their numbers in this assay, from the lowest: compounds 1, 4 and 2 (each within the scatter of the next); then compound 3.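

In this assay, going by these compounds alone, the exchange of 3,4-difluorophenyl for 3,4-dichlorophenyl on the saturated ring carbon gives a 1.1-fold lower number from compound 2 to compound 4 (0.02 log units; within the scatter) and is the first measured step at this aromatic ring rather than on the chain. With the 2-hydroxyethyl group held constant, this position accepts chlorine in place of fluorine at both ring sites with no change beyond the scatter. Nothing shown gives a measured reason for this result.

The compounds shown leave open whether this aromatic ring would accept a different kind of substituent, such as a methoxy group or an amine, instead of a halogen. Going by these compounds, it also remains open whether the same exchange would give a similar result alongside the methylcarbamoyl-bearing chain of compound 3.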